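Swapping (trifluoromethyl)sulfanyl for carboxy in compound 3

This account rests on a few compounds, and the source may have more. Where it says the series, first, only, none or still open, it means among the compounds named here.

Values in an ADME assay on Raji cells (Homo sapiens) for cytotoxicity, with a stated time of 72 h (on this read-out higher numbers stand for an effect only at larger amounts of compound and lower numbers for an effect already at smaller amounts), for the measured compounds:
compound 1 `Cc1cc(NC(=O)Nc2ccc(C(F)(F)F)cc2)c2ccccc2n1` gives 23000 nM
compound 2 `Cc1cc(NC(=O)Nc2ccc(O)cc2)c2ccccc2n1` gives > 25000 nM (a limit of the assay)
compound 3 `Cc1cc(NC(=O)Nc2ccc(SC(F)(F)F)cc2)c2ccccc2n1` gives 10000 nM

Of the two true numbers in this assay the lower belongs to compound 3 with 10000 nM and the other to compound 1. For compound 2 the assay reports only a limit, > 25000 nM and no number.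

Compound 4 `Cc1cc(NC(=O)Nc2ccc(C(=O)O)cc2)c2ccccc2n1` is still to be measured. It carries carboxy in place of (trifluoromethyl)sulfanyl on an aromatic carbon and otherwise matches compound 3.

Within the data shown here, two measured steps bear on this change. Hydroxy gave way to (trifluoromethyl)sulfanyl in an at least 2.5-fold lower number from compound 2 to compound 3 (0.39 log units; beyond the scatter) and trifluoromethyl gave way to it in a 2.3-fold lower number from compound 1 to compound 3 (0.36 log units; beyond the scatter) as well. Read in reverse, both show the number rising when (trifluoromethyl)sulfanyl leaves. The third step was an at least 1.0-fold higher number from compound 1 to compound 2 (0.03 log units; that floor lies within the scatter) and so adds little.

With carboxy entering, a step of at least modest size towards a higher number is therefore expected in this assay and the assay may well report only a limit. The expected step is a 3.0-fold higher number from compound 3 to compound 4 (0.48 log units; beyond the scatter) on this reasoning. For compound 4 the estimate is 30000 nM with an expected range from 14000 nM to 60000 nM overall.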

Compound 4, half-maximal effective concentration: > 25000 nM
Compound 4 ended at the assay's limit (the forecaster's own chance of this, stated with the estimate: 65%); the middle value is on the limit's open side.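

In this assay, the change from (trifluoromethyl)sulfanyl to carboxy on this aromatic carbon, para to a large group, gives an at least 2.5-fold higher number from compound 3 to compound 4 (0.39 log units; beyond the scatter), so the lower number of compound 3 is now set against a second replacement that ends at a limit, not only against hydroxy. Trifluoromethyl and carboxy are not separated by this result: an at least 1.0-fold higher number from compound 1 to compound 4 (0.03 log units; that floor lies within the scatter), so compound 1 and compound 4 cannot be placed in order. Compound 4 gives a limit of the assay, as compound 2 does, so the step between these two cannot be read, and two different groups at this position now end in the same place: the limit of > 25000 nM in this assay, at which 2 of the 4 values shown sit.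

As far as these compounds go, how far the true numbers of compound 2 and compound 4 lie past that limit stays open, and so does any ranking of hydroxy against carboxy. Also open, from the compounds shown here alone, is whether an amine, a methyl ester or a longer chain at this position would give a true number in this assay, and whether any such group would come near compound 3 at 10000 nM.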